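The compounds below may be only part of what the source reports. "The series", "measured", "known", "first", "only" and "open" are said of these compounds alone.

Working notes on the series. Among the compounds with values here, in a functional assay on MCF7 cells (Homo sapiens) for antiproliferative activity, read by sulforhodamine B assay, with a stated time of 48 h (a higher number here means a weaker inhibitor, a lower number a stronger inhibitor), two compounds built on the shared core have numbers so far: compound 1 (`Cc1cccc(OS(=O)(=O)c2ccc(N3CCN(C)C3=O)cc2)c1`) gives 5100 nM, and compound 2 (`COc1ccc(OS(=O)(=O)c2ccc(N3CCN(C)C3=O)cc2)cc1OC`) gives 12000 nM. Compound 2 therefore holds the higher of the two numbers, and its gap to compound 1 lies beyond the usual scatter.

Compound 3 (`COc1ccc(OS(=O)(=O)c2ccc(N3CCN(C)C3=O)cc2)cc1`) has not yet been measured in this assay. It departs from compound 2 by a single change: hydrogen in place of methoxy on an aromatic carbon. This is hydrogen in place of methoxy on an aromatic carbon, ortho to a methoxy group and meta to a large group.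

Within the data shown here, no measured pair isolates this change, so its size remains uncertain. A modest step toward a lower number is expected. Among the measured compounds shown here, the only support is compound 1 at 5100 nM, which differs from compound 2 in more than this one place. The expected change is a 2.2-fold lower number from compound 2 to compound 3 (0.34 log units; beyond the scatter). For compound 3 the estimated value is 5500 nM, with an expected range of 2000 nM to 14000 nM.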

Compound 3, half-maximal inhibitory concentration: 95000 nM
Compound 3: the middle estimate sits 17-fold (1.24 log units) below what was measured; measured number above the stated range.
By their numbers in this assay, from the lowest: compound 1; then compound 2; then compound 3.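

In this assay, the methoxy group that leaves, ortho to a methoxy group and meta to a large group, turns out to matter: hydrogen in place of methoxy on this aromatic carbon gives a 7.9-fold higher number from compound 2 to compound 3 (0.90 log units; beyond the scatter), so compound 3 is the weaker of this pair, and the position does not tolerate simple removal of the group. The other step, 4-methoxyphenyl in place of 3-methylphenyl on an oxygen, is larger at a 19-fold higher number from compound 1 to compound 3 (1.27 log units; beyond the scatter), and compound 3 now holds the highest number of the three, with its steps to both others beyond the scatter. Nothing measured on these compounds accounts for either step.

The compounds shown leave open whether the loss is specific to methoxy at this position, or whether a chlorine atom, an amine or a longer chain such as ethoxy on the same carbon would hold the number as well. They also leave open how a lone methyl group on this carbon would compare with the methoxy group, as the step from compound 1 replaces the whole aryl group.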